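Pyrazolyl for pyrrolyl at the indole two-position

This account rests on a few compounds, and the source may have more. Where it says the series, first, only, none or still open, it means among the compounds named here.

Three compounds of the series have numbers in a functional assay on LoVo cells (Homo sapiens) for cytotoxicity, read by MTT assay, with a stated time of 72 h; on this read-out lower numbers stand for stronger inhibition and higher numbers for weaker inhibition. Compound 1 `COc1ccc2[nH]c(-c3ccc[nH]3)c(C3CC(=O)NC3=O)c2c1` gives 4000 nM. Compound 2 `COc1ccc2[nH]c(-c3ccc[nH]3)cc2c1`, which keeps the same core but carries hydrogen in place of the 2,5-dioxopyrrolidin-3-yl group, gives 26000 nM; the step is a 6.5-fold higher number from compound 1 to compound 2 (0.81 log units; beyond the scatter). Compound 3 `Cc1ccc2[nH]c3c4cn[nH]c4c4c(c3c2c1)C(=O)NC4=O`, built on a different fused core, gives 5000 nM. Among these three numbers compound 2 has the highest, its nearest neighbour being compound 3 and the furthest compound 1, both of them beyond the scatter.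

The next compound, compound 4 `COc1ccc2[nH]c(-n3cccn3)cc2c1`, departs from compound 2 by 1H-pyrazol-1-yl in place of 1H-pyrrol-2-yl on an aromatic carbon.

Going by the values given here, no measured step touches this position: the single step on record, from compound 1 to compound 2, concerns the 2,5-dioxopyrrolidin-3-yl group on another carbon of the core, and compound 3 differs in the whole ring system. Among the compounds with values here, an exchange of one five-membered aromatic ring for another of the same size, with the core otherwise unchanged, therefore has no precedent here, and no step beyond the scatter is expected in this assay in either direction, with some lean toward a weaker number.

Compound 4 is thus expected to give 35000 nM, within 12000 nM to 100000 nM, the estimated step being a 1.3-fold higher number from compound 2 to compound 4 (0.13 log units; within the scatter).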

Compound 4, half-maximal inhibitory concentration: 70000 nM
Compound 4: the middle estimate sits 2.0-fold (0.30 log units) below what was measured; the range from low to high includes it.
By their numbers in this assay, from the lowest: compounds 1 and 3 (each within the scatter of the next); then compound 2; then compound 4.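

In this assay, going by these compounds alone, the exchange at this aromatic carbon next to the ring nitrogen gives a 2.7-fold higher number from compound 2 to compound 4 (0.43 log units; beyond the scatter), the first reading at this position, and it shows that swapping one five-membered aromatic ring for another is not neutral here, even with the heavy atom count of the group unchanged. Within the data shown here, the earlier step spoke only to the 2,5-dioxopyrrolidin-3-yl group, whereas this one shows that the number also responds to the identity of the ring at this position. 1H-pyrrol-2-yl and 1H-pyrazol-1-yl differ in ring hetero atoms, in hydrogen-bond donors and acceptors, and in the atom through which they attach, and no measurement on these compounds bears on which of these differences goes with the step.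

On these data alone, it remains open whether a 1H-pyrazol-3-yl or a plain phenyl ring at this position would read like compound 2 or like compound 4, which would help separate those differences. As far as these compounds go, it is also open whether the gain seen with the 2,5-dioxopyrrolidin-3-yl group, read in reverse from a 6.5-fold higher number from compound 1 to compound 2 (0.81 log units; beyond the scatter), carries over when 1H-pyrazol-1-yl occupies this position.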